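A 2-bromophenyl swap in a well-tolerated set

The source may hold more compounds than are shown below. What is called first, only, known or untested is meant among the compounds shown, and "the series" means these compounds.

For the measured compounds named here, in a functional assay on C8166 cells (Homo sapiens) for cytotoxicity, read by MTT assay, with a stated time of 72 h (a lower number here means that less compound is tolerated, a higher number that more compound is tolerated), compound 3 `COc1cc(/C=N/NC(=O)[C@@H]2CC3(CN2S(=O)(=O)c2ccc(C)cc2)SCCS3)cc(OC)c1OC` gives 327000 nM, the only exact number among the three compounds measured so far. Compound 1 `Cc1ccc(S(=O)(=O)N2CC3(C[C@H]2C(=O)N/N=C/c2ccccc2Cl)SCCS3)cc1` is reported only as a limit, > 404000 nM. Compound 2 `Cc1ccc(S(=O)(=O)N2CC3(C[C@H]2C(=O)N/N=C/c2cccc([N+](=O)[O-])c2)SCCS3)cc1` is also reported only as a limit, > 395000 nM.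

Compound 4 `Cc1ccc(S(=O)(=O)N2CC3(C[C@H]2C(=O)N/N=C/c2ccccc2Br)SCCS3)cc1` has not yet been measured. It carries 2-bromophenyl in place of 3,4,5-trimethoxyphenyl on a carbon with a double bond to nitrogen.

The closest guide is the swap of 2-chlorophenyl for 3,4,5-trimethoxyphenyl, an at least 1.2-fold lower number from compound 1 to compound 3 (0.09 log units; that floor lies within the scatter). The group leaving there is the nearest named relative of 2-bromophenyl, and the change here runs the opposite way. The swap from 3-nitrophenyl, an at least 1.2-fold lower number from compound 2 to compound 3 (0.08 log units; that floor lies within the scatter), adds a second reading. Both are only floors and stay within the scatter, so neither shows a real effect.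

The expected result is a 1.1-fold higher number from compound 3 to compound 4 (0.04 log units; within the scatter), with no step beyond the scatter in this assay. For compound 4 the estimated value is 360000 nM, with an expected range of 220000 nM to 450000 nM.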

Compound 4, half-maximal cytotoxic concentration: 177000 nM
Compound 4: middle estimate off by 2.0-fold (0.31 log units), on the high side; measured number below the stated range.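

In this assay, for the compounds shown here, the change of bromo in place of chloro on an aromatic carbon gives the first step in this set that is readable beyond the scatter, an at least 2.2-fold lower number from compound 1 to compound 4 (0.35 log units; beyond the scatter), and the swap from 3-nitrophenyl reads the same way, an at least 2.2-fold lower number from compound 2 to compound 4 (0.34 log units; beyond the scatter). Compounds 1 and 2 are both held only as limits, so those two steps are floors and not full sizes. The swap from 3,4,5-trimethoxyphenyl gives a 1.8-fold lower number from compound 3 to compound 4 (0.27 log units; within the scatter), so those two groups cannot be told apart at this place.

Going by these compounds alone, how far the bromo compound really lies from its chloro partner stays open, since only one side of that pair has a number. Also open, as far as these compounds go, is what a 2-iodophenyl group or a phenyl ring carrying an amine would give on this carbon.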